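A few compounds are considered here, and "the series" means these few. Any claim that something is new, unique, unknown or untested is made for them only; others in the source may bear on it.

Among the measured compounds shown here, compound 1 `O=C1C=C(Nc2ccc(I)cc2)C(=O)c2c1nc1n2[C@H]2OC[C@@H](O)[C@H]2OC1` is one of three compounds measured in a functional assay on MGC-803 cells (Homo sapiens) for inhibition, read by sulforhodamine B assay; on this read-out higher numbers stand for weaker inhibition and lower numbers for stronger inhibition. In this assay compound 1 gives 1400 nM. Compound 2 `Cc1ccc(NC2=CC(=O)c3c(nc4n3[C@H]3OC[C@@H](O)[C@H]3OC4)C2=O)cc1C` gives 1050 nM, and compound 3 `O=C1C(Nc2ccccc2)=CC(=O)c2c1nc1n2[C@H]2OC[C@@H](O)[C@H]2OC1` gives 1830 nM; the three numbers lie within the usual scatter of one another, so no ordering among them can be read from the data.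

Compound 4 `COc1ccc(NC2=CC(=O)c3nc4n(c3C2=O)[C@H]2OC[C@@H](O)[C@H]2OC4)cc1` differs from compound 1 in a single way: methoxy in place of iodo on an aromatic carbon. For the measured compounds named here, no measured step exchanges these two groups. Going by the values given here, the one measured step, a 1.7-fold higher number from compound 2 to compound 3 (0.24 log units; within the scatter), alters the substitution of the group on the amine nitrogen and stays within the scatter. Among the compounds with values here, that is the only guide available, and it suggests that changes of the aryl substitution on this amine have so far produced no step beyond the scatter.

Compound 4 is therefore expected to stay close to compound 1, with an estimated step of no change at the digits printed from compound 1 to compound 4 (within the scatter). The estimate for compound 4 in this assay is 1400 nM, within a range from 600 nM to 3200 nM.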

Compound 4, half-maximal inhibitory concentration: 1680 nM
The estimate for compound 4 lay 1.2-fold (0.08 log units) below the measured number, and the stated range covers the measured number.
By their numbers in this assay, from the lowest: compounds 2, 1, 4 and 3 (each within the scatter of the next).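

In this assay, among the compounds shown here, the exchange of 4-iodophenyl for 4-methoxyphenyl on the amine nitrogen gives a 1.2-fold higher number from compound 1 to compound 4 (0.08 log units; within the scatter) and is the first direct comparison of two different groups on this aromatic carbon. Methoxy brings an oxygen and a hydrogen-bond acceptor that iodo lacks, yet the read-out does not separate the two groups, and this step joins a 1.7-fold higher number from compound 2 to compound 3 (0.24 log units; within the scatter) as a second change of the aryl group that stays within the scatter. Nothing available bears on why these two groups read alike.

The compounds shown leave open whether any group on this carbon can produce a step beyond the scatter. A carboxylic acid, a dimethylamino group or a longer alkoxy chain there would test this.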